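The source may report more compounds than this note shows. Statements on the series, on what has been measured and on what is new or still open speak of the compounds shown alone.

In a functional assay on the whole organism with Rattus norvegicus as the target (on this read-out lower numbers stand for an effect already at smaller amounts and higher numbers for an effect only at larger amounts of compound), compound 2 `CCOCCOC(=O)C(=O)Nc1nc(-c2cc(-c3ccccc3)on2)cs1` gives 13 mg/kg and compound 3 `CCOCCOC(=O)C(=O)Nc1nc(-c2cc(CO)on2)cs1` gives 14 mg/kg, two numbers that lie within the scatter of each other. Compound 1 `CCOC(=O)C(=O)Nc1nc(-c2cc(Br)no2)cs1` reaches only a limit, > 100 mg/kg. Compound 4 `O=C(O)C(=O)Nc1nc(-c2cc(-c3ccccc3)on2)cs1` departs from compound 2 at the ester: hydrogen in place of 2-ethoxyethyl on an oxygen next to a carbonyl group. Going by the values given here, the only measured step, a 1.1-fold higher number from compound 2 to compound 3 (0.03 log units; within the scatter), replaces phenyl with hydroxymethyl on an aromatic carbon, so it does not touch this place and gives only weak guidance. The expected change, a 1.2-fold higher number from compound 2 to compound 4 (0.06 log units; within the scatter), is therefore no larger than the scatter, with no firm direction. For compound 4 the estimate is 15 mg/kg, with an expected range of 3 mg/kg to 70 mg/kg.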

Compound 4, dose for half-maximal effect: 2.6 mg/kg
Beside the measured number, compound 4's estimate is 5.8-fold (0.76 log units) above it; the measured number lies below the stated range.
By their numbers in this assay, from the lowest: compound 4; then compounds 2 and 3 (each within the scatter of the next). At a limit, above all of these: compound 1.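

In this assay, exchanging 2-ethoxyethoxy for hydroxy gives a 5.0-fold lower number from compound 2 to compound 4 (0.70 log units; beyond the scatter). Going by these compounds alone, the only earlier step, a 1.1-fold higher number from compound 2 to compound 3 (0.03 log units; within the scatter), concerned a different place and stayed within the scatter, so this is the first sign that the number responds to a change in the shared core's substituents. On this core, the carboxy group goes with an effect at smaller amounts than (2-ethoxyethoxy)carbonyl. On these data alone, whether a methyl ester or a primary amide at this place would follow compound 4 or compound 2 remains open. The data shown offer no reason for the step.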